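Nitrooxy to hydroxy on the side chain of compound 3

The source may hold more compounds than are shown below. What is called first, only, known or untested is meant among the compounds shown, and "the series" means these compounds.

Compound 3 `Cc1c(CC[S+]([O-])CCO[N+](=O)[O-])cc(-c2ccc(S(C)(=O)=O)cc2)n1-c1ccccc1` carries a 2-(nitrooxy)ethyl group on its side chain. In an assay on J774 cells for inhibition of prostaglandin G/H synthase 1 (Mus musculus), read by immunoassay, with stated times of 15 min and 30 min (on this read-out higher numbers stand for weaker inhibition and lower numbers for stronger inhibition), compound 3 gives > 10000 nM, which is a limit of the assay and not a number. Two close relatives are compound 1 `Cc1c(CCSCCO[N+](=O)[O-])cc(-c2ccc(S(C)(=O)=O)cc2)n1-c1ccccc1` and compound 2 `Cc1c(CCSCCO)cc(-c2ccc(S(C)(=O)=O)cc2)n1-c1ccccc1`. In this assay compound 1 gives > 10000 nM, again a limit. Compound 2 gives > 10000 nM, also a limit. All three values thus sit at the limit of > 10000 nM in this assay, at which 3 of the 3 values shown sit, and none of the three compounds can be placed above or below another.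

The step to compound 4 `Cc1c(CC[S+]([O-])CCO)cc(-c2ccc(S(C)(=O)=O)cc2)n1-c1ccccc1` is hydrogen in place of nitro on an oxygen on a saturated carbon. The same change has already been made once in the series, from compound 1 to compound 2 with a step that the two limits leave unreadable from compound 1 to compound 2. The neighbouring steps a step that the two limits leave unreadable from compound 1 to compound 3 and a step that the two limits leave unreadable from compound 2 to compound 3 are unreadable as well. Going by the values given here, no measured step therefore gives a size or direction for this change, so compound 4 is expected to stay at the limit, with an expected step that the limit leaves unreadable from compound 3 to compound 4 that cannot be read beyond the scatter. Compound 4 is estimated at 15000 nM, within 5000 nM to 50000 nM, and will most probably be reported only as a limit.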

Compound 4, half-maximal inhibitory concentration: > 10000 nM
Compound 4 gave a limit, no number (the forecaster's own chance of this, stated with the estimate: 85%); the middle value is on the limit's open side.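

No step from compound 1, compound 2 or compound 3 to compound 4 can be read in this assay, and the four compounds cannot be ordered: the limit of > 10000 nM in this assay, at which 4 of the 4 values shown sit.

The compounds shown leave open whether nitrooxy to hydroxy changes inhibition at all, and in which direction.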